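Longer ester chains on the shared bicyclic core

A few compounds are considered here, and "the series" means these few. Any claim that something is new, unique, unknown or untested is made for them only; others in the source may bear on it.

Compound 1 `CC(=O)O[C@]12C=CC(O)C[C@H]1OCC2` and compound 2 `CCCCCC(=O)O[C@]12C=CC(O)C[C@H]1OCC2` share one core and differ only in the ester chain. In a functional assay on HeLa S3 cells (Homo sapiens) for cytotoxicity (on this read-out lower numbers stand for stronger inhibition and higher numbers for weaker inhibition), compound 1 gives only a limit, > 100 ug/mL, namely (the limit of > 100 ug/mL in this assay, at which 1 of the 2 values shown sits). In this assay, for the measured compounds named here, compound 2 gives 5.3 ug/mL, the one number in the set. The step of an at least 18-fold lower number from compound 1 to compound 2 (1.27 log units; beyond the scatter) arose from butyl in place of hydrogen on a saturated chain carbon bound to a carbonyl carbon. Compound 3 `CCCCCCCC(=O)O[C@]12C=CC(O)C[C@H]1OCC2` carries ethyl in place of hydrogen on a saturated chain carbon, five bonds along the chain from a carbonyl carbon relative to compound 2. Going by the values given here, only that one measured step bears on chain length, and it was large; a smaller step in the same direction is expected, a 1.8-fold lower number from compound 2 to compound 3 (0.25 log units; within the scatter). Compound 3 is therefore estimated at 3 ug/mL, ranging from 1 ug/mL to 12 ug/mL.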

Compound 3, half-maximal inhibitory concentration: 3.5 ug/mL
Beside the measured number, compound 3's estimate is 1.2-fold (0.07 log units) below it, within the range that was stated.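

In this assay, ethyl in place of hydrogen on a saturated chain carbon, five bonds along the chain from a carbonyl carbon, gives a 1.5-fold lower number from compound 2 to compound 3 (0.18 log units; within the scatter), so this further lengthening adds no readable change. Taken over the whole difference in the ester chain, the step reads an at least 28-fold lower number from compound 1 to compound 3 (1.45 log units; beyond the scatter), so the large drop already appears with butyl and does not measurably grow with the added ethyl. The value of compound 1 is a limit, not a number: the limit of > 100 ug/mL in this assay, at which 1 of the 3 values shown sits.

Still open, from the compounds shown here alone, is whether a longer chain than that of compound 3 holds this level or loses it, and how a chain ending in an amine or a carboxylic acid would read.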